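The source may report more compounds than this note shows. Statements on the series, on what has been measured and on what is new or still open speak of the compounds shown alone.

Compound 1 `CCC(=O)N(Cc1ccc(OC)c(O)c1)c1cc(OC)c(OC)c(OC)c1` stands at the lowest number of the two compounds measured in a functional assay on HCT-116 cells (Homo sapiens) for inhibition, read by MTT assay, with a stated time of 48 h; on this read-out higher numbers stand for weaker inhibition and lower numbers for stronger inhibition: compound 1 gives 61 nM. The other measured compound, compound 2 `C/C=C/C(=O)N(Cc1ccc(OC)c(Br)c1)c1cc(OC)c(OC)c(OC)c1`, gives 2800 nM in this assay, a much higher number that lies well beyond the scatter. Compound 3 `COc1ccc(CN(C(=O)CBr)c2cc(OC)c(OC)c(OC)c2)cc1O` has not yet been measured. It differs from compound 1 in one place: bromo in place of methyl on a saturated chain carbon bound to a carbonyl carbon. For the measured compounds named here, no measured pair shows this change, so nothing is known of its effect. The step from compound 1 to compound 3 is expected to be modest, a 2.5-fold higher number from compound 1 to compound 3 (0.39 log units; beyond the scatter), toward a somewhat higher number. Compound 3 is therefore estimated at 150 nM, with a range from 30 nM to 800 nM.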

Compound 3, half-maximal inhibitory concentration: 68 nM
For compound 3 the middle estimate is 2.2-fold (0.34 log units) above the measured one, within the range that was stated.
By their numbers in this assay, from the lowest: compounds 1 and 3 (each within the scatter of the next); then compound 2.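

In this assay, bromo in place of methyl on a saturated chain carbon bound to a carbonyl carbon gives a 1.1-fold higher number from compound 1 to compound 3 (0.05 log units; within the scatter) and so leaves the number unchanged within the scatter. For the compounds shown here, this is the first pair to show that this position can carry a group other than methyl while the number stays in the range of compound 1. Nothing measured here offers an explanation for this result. Still open, from the compounds shown here alone, is how other groups at this place, such as chloro, an amine, a carboxylic acid or a longer chain, would read in this assay.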